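The source may report more compounds than this note shows. Statements on the series, on what has been measured and on what is new or still open speak of the compounds shown alone.

In a functional assay on NPC-TW01 cells (Homo sapiens) for inhibition, read by MTT assay, with a stated time of 72 h (on this read-out higher numbers stand for weaker inhibition of growth and lower numbers for stronger inhibition of growth), two compounds sharing one core have been measured so far. Compound 1 `Cc1ccc(-c2nn(-c3cccc(Cl)c3)c(/N=C/N(C)C)c2C=O)cc1` gives 7200 nM, and compound 2 `Cc1ccc(-c2nn(-c3ccc(Br)cc3)c(/N=C/N(C)C)c2C=O)cc1` gives 6000 nM, which places compound 2 level with compound 1 within the scatter. Within the data shown here, the only measured step, a 1.2-fold lower number from compound 1 to compound 2 (0.08 log units; within the scatter), changes just the group on the ring nitrogen.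

Compound 3 `Cc1ccc(-c2cc(/N=C/N(C)C)n(-c3ccc(Br)cc3)n2)cc1` keeps the 4-bromophenyl and 4-methylphenyl groups of compound 2 but carries hydrogen in place of formyl on an aromatic carbon. The measured step does not touch this carbon, and both measured compounds carry the formyl group, so the data give no direct measure of losing it. The small size of a 1.2-fold lower number from compound 1 to compound 2 (0.08 log units; within the scatter) therefore sets no limit on the new step. A moderate move towards a higher number, meaning weaker inhibition of growth, is expected, though with wide uncertainty. The expected change is a 2.5-fold higher number from compound 2 to compound 3 (0.40 log units; beyond the scatter). For compound 3 the estimated value is 15000 nM, with an expected range from 5000 nM to 50000 nM.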

Compound 3, concentration for 50% growth inhibition: > 100000 nM
Compound 3 gave a limit, no number; the forecaster's own chance of this, stated with the estimate: 20%; middle value at least 6.6-fold (0.82 log units) away from the limit.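

Among these compounds, the formyl group on this aromatic carbon was common to both earlier compounds, so its replacement is the first change at this position, and in this assay hydrogen in its place gives an at least 16-fold higher number from compound 2 to compound 3 (1.22 log units; beyond the scatter), a large step beyond the scatter. For compound 3 the result is a limit of the assay and not a number: the limit of > 100000 nM in this assay, at which 1 of the 3 values shown sits. The only earlier step, on the ring nitrogen, is a 1.2-fold lower number from compound 1 to compound 2 (0.08 log units; within the scatter) and lies within the scatter, so among these three compounds the aromatic carbon is the one place where a change has shifted growth inhibition beyond the scatter, with the loss of the formyl group taking it out of the measurable range.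

With a limit in place of a number, the full size of this step remains unknown, and hydrogen is the only replacement for formyl shown here. On these data alone, whether a hydroxymethyl group, a carboxylic acid or a nitrile on this carbon would retain the growth inhibition stays open, as does whether the same loss would appear with the 3-chlorophenyl group on the ring nitrogen.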